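Trading a Trifluoromethoxyphenyl for a Trifluoromethylphenyl

A few compounds are considered here, and "the series" means these few. Any claim that something is new, unique, unknown or untested is made for them only; others in the source may bear on it.

Of the compounds shown here, three sharing one core have been tested in a functional assay on MCF7 cells (Homo sapiens) for cytotoxicity, read by MTT assay, with a stated time of 72 h; on this read-out higher numbers stand for weaker inhibition and lower numbers for stronger inhibition. Compound 1 `Cc1cc(=O)n(-c2cccc(C(F)(F)F)c2)nc1C(=O)Nc1ccc(Oc2ncnc3[nH]ccc23)cc1` gives 4560 nM, compound 2 `Cc1cc(=O)n(-c2cccc(F)c2)nc1C(=O)Nc1ccc(Oc2ncnc3[nH]ccc23)c(F)c1` gives 32000 nM, and compound 3 `Cc1cc(=O)n(-c2ccccc2OC(F)(F)F)nc1C(=O)Nc1ccc(Oc2ncnc3[nH]ccc23)c(F)c1` gives 11700 nM. Compound 3 thus stands second highest of the three numbers, nearer to compound 1 than to compound 2. Going by the values given here, the one measured step, a 2.7-fold lower number from compound 2 to compound 3 (0.44 log units; beyond the scatter), shows that the group on the aromatic nitrogen can shift the read-out by a modest amount.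

Compound 4 `Cc1cc(=O)n(-c2cccc(C(F)(F)F)c2)nc1C(=O)Nc1ccc(Oc2ncnc3[nH]ccc23)c(F)c1` carries the change (3-(trifluoromethyl)phenyl in place of 2-(trifluoromethoxy)phenyl on an aromatic nitrogen). Among the compounds with values here, no measured step matches this exchange directly; compound 1, which bears the same 3-(trifluoromethyl)phenyl group, lies lower than compound 3, while compound 2 shows that the added fluorine on the central ring accompanies a high number. Weighing both, compound 4 is expected to land close to compound 3, with a 1.3-fold lower number from compound 3 to compound 4 (0.11 log units; within the scatter), a shift not beyond the scatter. Compound 4 is estimated at 9000 nM in this assay, within a range of 3500 nM to 25000 nM.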

Compound 4, half-maximal inhibitory concentration: 11800 nM
Beside the measured number, compound 4's estimate is 1.3-fold (0.12 log units) below it, within the range that was stated.
By their numbers in this assay, from the lowest: compound 1; then compounds 3 and 4 (each within the scatter of the next); then compound 2.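

In this assay the exchange of 2-(trifluoromethoxy)phenyl for 3-(trifluoromethyl)phenyl on the aromatic nitrogen gives a 1.0-fold higher number from compound 3 to compound 4 (0.00 log units; within the scatter), so at this position the two groups cannot be told apart on this read-out, although their substituents differ in kind and place. Going by these compounds alone, the other two steps show that the number still responds to single changes: trifluoromethyl in place of fluoro gives a 2.7-fold lower number from compound 2 to compound 4 (0.43 log units; beyond the scatter), and fluoro in place of hydrogen on an aromatic carbon, seen alone for the first time here, gives a 2.6-fold higher number from compound 1 to compound 4 (0.41 log units; beyond the scatter). Nothing available explains these shifts or the lack of one.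

From the compounds shown here alone, whether an amine or a carboxylic acid on the phenyl ring would move the number remains open. So does whether the fluoro step would be the same size with a different group on the aromatic nitrogen.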